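This account rests on a few compounds, and the source may have more. Where it says the series, first, only, none or still open, it means among the compounds named here.

Of the compounds shown here, three sharing one core have been tested in a functional assay on Jurkat cells (Homo sapiens) for antiproliferative activity, read by MTT assay, with a stated time of 72 h; on this read-out higher numbers stand for weaker inhibition and lower numbers for stronger inhibition. Compound 1 `C=C(Br)C(=O)Nc1ccc2c(c1)/C(=C/c1cccs1)C(=O)N2` gives 210 nM. Compound 2 `C=C(Br)C(=O)Nc1ccc2c(c1)/C(=C\c1cccs1)C(=O)N2` has the same atoms and bonds and gives 616 nM; the step of a 2.9-fold higher number from compound 1 to compound 2 (0.47 log units; beyond the scatter) rests only on how the double bond is drawn (the fact that compounds 1 and 2 differ only in the configuration as drawn). Compound 3 `C=C(Br)C(=O)Nc1ccc2c(c1)/C(=C/c1sccc1C)C(=O)N2` carries a methyl in place of hydrogen on an aromatic carbon and gives 530 nM, so that a 2.5-fold higher number from compound 1 to compound 3 (0.40 log units; beyond the scatter). Compound 2 thus shows the highest of the three numbers, though its gap to compound 3 is within the scatter, while its gap to compound 1 lies beyond it.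

Compound 4 `C=C(Br)C(=O)Nc1ccc2c(c1)/C(=C\c1ccc(C)s1)C(=O)N2` is not yet measured. It keeps the drawn configuration of compound 2 and differs from it by methyl in place of hydrogen on an aromatic carbon, so thiophen-2-yl becomes 5-methylthiophen-2-yl. Among the compounds with values here, the only measured step of the same kind is a 2.5-fold higher number from compound 1 to compound 3 (0.40 log units; beyond the scatter), also methyl in place of hydrogen on an aromatic carbon, though at another position, and there the number rose modestly. A step of similar size and direction is therefore expected, namely a 1.8-fold higher number from compound 2 to compound 4 (0.25 log units; within the scatter). Compound 4 is estimated at 1100 nM in this assay, with a likely range from 450 nM to 2700 nM.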

Compound 4, half-maximal inhibitory concentration: 150 nM
Estimate against measurement, compound 4: 7.3-fold (0.87 log units) above; measured number outside the range, below it.
By their numbers in this assay, from the lowest: compounds 4 and 1 (each within the scatter of the next); then compounds 3 and 2 (each within the scatter of the next).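

In this assay, changing thiophen-2-yl to 5-methylthiophen-2-yl gives a 4.1-fold lower number from compound 2 to compound 4 (0.61 log units; beyond the scatter). A methyl in place of hydrogen on this ring can therefore go with stronger inhibition as well as weaker, and this position, next to the ring sulfur, tolerates the added carbon on the core of compound 2. The same kind of change thus has no single effect across these compounds, and a step seen in one compound cannot simply be carried over to another: the same change on two cores in this assay, a 2.5-fold higher number (0.40 log units; beyond the scatter) from compound 1 to compound 3 and a 4.1-fold lower number (0.61 log units; beyond the scatter) from compound 2 to compound 4, 10-fold (1.02 log units) apart, beyond the scatter of two such steps.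

Compound 3 and compound 4 differ both in where the methyl sits and in how the double bond is drawn, and the compounds shown do not separate these two factors, so either one, or both together, could lie behind the opposite steps. On these data alone, it also remains open how far this position tolerates change, for instance whether an ethyl, a chlorine or an amine in place of the methyl would keep the number low, or whether the same methyl would lower it on the core of compound 1.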